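Replacing an aryl urea terminus with a morpholine amide

A few compounds are considered here, and "the series" means these few. Any claim that something is new, unique, unknown or untested is made for them only; others in the source may bear on it.

Compound 2, `CC1(C)N=C(N)N=C(N)N1c1cccc(CNC(=O)Nc2cccc(C#N)c2)c1`: 8.19
Compound 1, `CC1(C)N=C(N)N=C(N)N1c1ccc(OCCCOc2ccc(S(=O)(=O)F)cc2)c(Cl)c1`: 7.07

Two measured compounds share the same core. In an assay on isolated protein for inhibition of Dihydrofolate reductase (Mus musculus) (on this read-out lower numbers stand for lower potency and higher numbers for higher potency (the scale is a negative logarithm)), compound 2 gives 8.19, the highest of the two numbers, and compound 1 gives 7.07, a value that lies below compound 2 by more than the usual scatter. Among the compounds with values here, no pair differing in a single place has been measured, so no single-change step is known for this series.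

Compound 3, `CC1(C)N=C(N)N=C(N)N1c1cccc(CNC(=O)N2CCOCC2)c1`, has not yet been measured. It differs from compound 2 in one place: morpholin-4-yl in place of (3-cyanophenyl)amino on a carbonyl carbon. The group that leaves carries an aromatic ring, a nitrile and a hydrogen-bond donor; the group that enters is a saturated ring without a donor. The expectation is that this change costs potency in this assay, with a step from compound 2 to compound 3 of a number 0.89 log units lower from compound 2 to compound 3 (beyond the scatter), beyond the scatter. Compound 3 is therefore estimated at 7.3, within a range from 6.5 to 8.1.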

Compound 3, logarithm of the reciprocal of the active concentration, log(1/C): 6.43
Compound 3: middle estimate off by 0.87 log units, on the high side; measured number below the stated range.
By their numbers in this assay, from the lowest: compound 3; then compound 1; then compound 2.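

In this assay, within the data shown here, exchanging the terminal group on the carbonyl carbon gives a number 1.76 log units lower from compound 2 to compound 3 (beyond the scatter), the first single-change step and a large one, so potency here depends strongly on the group at this place. The change is not a single feature, however: an aromatic ring, a nitrile and a hydrogen-bond donor leave together, while a saturated ring without a donor enters, and the step does not separate their contributions. No measurement shown bears on the cause of this loss.

The compounds shown leave open whether plain phenylamino, which lacks the nitrile, would keep the potency of compound 2. They also leave open whether piperidin-1-yl or a saturated amine that keeps its nitrogen hydrogen, such as cyclohexylamino, would behave like compound 3.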